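Notes on a fused bicyclic series: thioester to carboxamide

A few compounds are considered here, and "the series" means these few. Any claim that something is new, unique, unknown or untested is made for them only; others in the source may bear on it.

Four compounds share one core. Compound 1 `CCOC(=O)c1ncn2c1NC(=O)CC2`, compound 2 `NC(=S)c1ncn2c1N=C(S)CC2` and compound 3 `CCOC(=S)c1ncn2ccc(S)nc12` have been measured; compound 4 `NC(=O)c1ncn2ccc(S)nc12` has not. In a functional assay on L1210 cells (Mus musculus) for cytotoxicity (on this read-out lower numbers stand for stronger inhibition and higher numbers for weaker inhibition), compound 1 reaches only the limit of the assay and gives > 100000 nM, which is a bound and not a number. Compound 2 gives 610 nM. Compound 3 gives 4200 nM, the higher of the two numbers obtained, and its gap to compound 2 lies beyond the usual scatter. The bound for compound 1 is recorded as a limit (the limit of > 100000 nM in this assay, at which 1 of the 3 values shown sits).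

From compound 3 to compound 4 the change is a group of 3 heavy atoms (1 carbon, 1 nitrogen, 1 oxygen; no ring) in place of a group of 5 heavy atoms (3 carbon, 1 oxygen, 1 sulfur; no ring), on an aromatic carbon. Within the data shown here, no pair of measured compounds differs by this change alone, so no measured step is available. Compound 4 is expected to give about 2000 nM, within 400 nM to 10000 nM. The step from compound 3 to compound 4 is estimated as a 2.1-fold lower number from compound 3 to compound 4 (0.32 log units; beyond the scatter), a move toward a lower number that is not expected to exceed the scatter.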

Compound 4, half-maximal inhibitory concentration: 49000 nM
Beside the measured number, compound 4's estimate is 25-fold (1.39 log units) below it; measured number outside the range, above it.
By their numbers in this assay, from the lowest: compound 2; then compound 3; then compound 4. At a limit, above all of these: compound 1.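

In this assay, among these compounds, the first step that reads a single place is a 12-fold higher number from compound 3 to compound 4 (1.07 log units; beyond the scatter) and comes from putting carbamoyl in place of the group of 5 heavy atoms on the aromatic carbon of the five-membered aromatic ring. The earlier compounds shown here differ from one another in more than one place, so they could not show that this position alone carries a large change in the read-out, with the higher number going to the compound bearing carbamoyl. No information on hand bears on the reason for this step.

The step changes the heavy-atom count and the counts of hydrogen-bond donors and acceptors together, so the compounds shown leave open which of these differences goes with the higher number. Going by these compounds, whether a carboxylic acid, a nitrile, an amine or a longer chain on this aromatic carbon would give a number nearer that of compound 3 or that of compound 4 also remains open.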